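A 2-chlorophenyl in place of 3-chlorophenyl

The source may report more compounds than this note shows. Statements on the series, on what has been measured and on what is new or still open speak of the compounds shown alone.

Measured in a functional assay on MCF7 cells (Homo sapiens) for inhibition, read by MTT assay, with a stated time of 48 h; a lower number here means a stronger inhibitor of growth, a higher number a weaker inhibitor of growth:
compound 1 `CN1CC[C@H](c2c(O)cc(O)c3c(=O)cc(/C=C/c4cccc(Cl)c4)oc23)[C@H](O)C1`: 2000 nM
compound 2 `CN1CC[C@H](c2c(O)cc(O)c3c(=O)cc(/C=C/c4ccccc4F)oc23)[C@H](O)C1`: 8000 nM

Compound 1 holds the lower of the two numbers, at 2000 nM. Going by the values given here, the only measured step is a 4.0-fold higher number from compound 1 to compound 2 (0.60 log units; beyond the scatter), with 2-fluorophenyl replacing 3-chlorophenyl. Compound 3 `CN1CC[C@H](c2c(O)cc(O)c3c(=O)cc(/C=C/c4ccccc4Cl)oc23)[C@H](O)C1` keeps the core of compound 1 and differs in one place: 2-chlorophenyl in place of 3-chlorophenyl on a double-bonded chain carbon bound to a double-bonded chain carbon. The measured step bears on this change only in part. Compound 3 carries a 2-substituted phenyl name as compound 2 does, but it keeps the chlorine of compound 1. The data do not separate these two features. A rise in this assay is therefore expected, smaller than a 4.0-fold higher number from compound 1 to compound 2 (0.60 log units; beyond the scatter). The expected step is a 2.0-fold higher number from compound 1 to compound 3 (0.30 log units; within the scatter). Compound 3 is estimated at 4000 nM, with an expected range of 1500 nM to 10000 nM.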

Compound 3, concentration for 50% growth inhibition: 9000 nM
Compound 3: the middle estimate sits 2.3-fold (0.35 log units) below what was measured; the measured number falls inside the stated range.
By their numbers in this assay, from the lowest: compound 1; then compounds 2 and 3 (each within the scatter of the next).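

In this assay, the two groups have the same atoms joined differently, and 2-chlorophenyl in place of 3-chlorophenyl gives a 4.5-fold higher number from compound 1 to compound 3 (0.65 log units; beyond the scatter). The arrangement of the chlorophenyl group alone therefore changes the number, which the earlier step could not show because it changed the halogen as well. Chloro in place of fluoro on an aromatic carbon gives a 1.1-fold higher number from compound 2 to compound 3 (0.05 log units; within the scatter), so the halogen makes no discernible difference between these two 2-substituted phenyl compounds. No evidence is given to explain these results.

The compounds shown leave open whether the lower number of compound 1 depends on chlorine, or whether a methoxy group or an amine in place of the chlorine of 3-chlorophenyl would give a similar value. An unsubstituted phenyl as a reference also lies outside the compounds shown.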